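A few compounds are considered here, and "the series" means these few. Any claim that something is new, unique, unknown or untested is made for them only; others in the source may bear on it.

Working notes on the series. Compound 1 `C=Cc1cn2ncc(-c3ccnc(OC)c3)c2nc1NC` and compound 2 `COc1cc(-c2cnn3cc(OC)c(-c4cc(C)no4)nc23)ccn1` are built on a shared core and have both been measured in an assay on isolated protein for inhibition of activin receptor type-2A (Homo sapiens), read by 33P incorporation, with a stated time of 20 min, in the presence of a further agent that is not named here; a lower number here means a stronger inhibitor, a higher number a weaker inhibitor. In that assay compound 1 gives 190 nM. Compound 2 gives 3000 nM in this assay, which is the higher of the two numbers, and the gap to compound 1 lies beyond the scatter. The two compounds differ from each other in more than one place at once, so the numbers say only where each stands and nothing about any single change. Compound 3 `COc1cc(-c2cnn3cc(OC)c(C4CCOC4)nc23)ccn1` has not been measured. It follows from compound 2 by one change: oxolan-3-yl in place of 3-methyl-1,2-oxazol-5-yl on an aromatic carbon. For the measured compounds named here, no measured pair in the set isolates a change at this place, so no step size can be read from the data. The step of a 1.5-fold higher number from compound 2 to compound 3 (0.18 log units; within the scatter) is expected to be small, toward a weaker inhibitor, and may not exceed the scatter. Compound 3 is accordingly estimated in this assay at 4500 nM, with a range from 1500 nM to 13000 nM.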

Compound 3, half-maximal inhibitory concentration: 1900 nM
Compound 3: the middle estimate sits 2.4-fold (0.37 log units) above what was measured; the range from low to high includes it.
By their numbers in this assay, from the lowest: compound 1; then compounds 3 and 2 (each within the scatter of the next).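

In this assay, for the compounds shown here, the exchange of 3-methyl-1,2-oxazol-5-yl for oxolan-3-yl, on the aromatic carbon ortho to a methoxy group, gives a 1.6-fold lower number from compound 2 to compound 3 (0.20 log units; within the scatter) and is the only step that can be read at this place. For this pair, the move from a five-membered aromatic ring with 2 hetero atoms to a five-membered non-aromatic ring with 1 hetero atom, with 5 heavy atoms instead of 6 and 1 hydrogen-bond acceptor instead of 2, does not separate the two compounds in this assay. No measurement available here bears on the reason for this result.

On these data alone, both groups seen at this place are five-membered rings containing oxygen, so the effect of a dimethylamino group, a carboxylic acid or a straight propyl chain on the same aromatic carbon remains open. Going by these compounds alone, compound 1 differs from compound 2 and compound 3 in more than one place, so no step to it can be read, and the contribution of each of its differing groups also remains open.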